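From cyclobutylmethyl to 3-fluorobenzyl: half-life outlook for compound 4

The compounds below may be only part of what the source reports. "The series", "measured", "known", "first", "only" and "open" are said of these compounds alone.

Measured so far in an in vitro ADME assay on microsomes from liver (Homo sapiens) for metabolic stability (a higher number here means that the compound lasts longer, a lower number that the compound disappears faster), as half-life
- compound 1 `CS(=O)(=O)Nc1ccc2c(c1)S(=O)(=O)N=C(C1=C(O)C3CCCC3N(Cc3ccc(F)cn3)C1=O)N2` gives > 1 h as a limit of the assay, not a number
- compound 2 `CC(C)CCN1C(=O)C(C2=NS(=O)(=O)c3cc(NS(C)(=O)=O)ccc3N2)=C(O)C2CCCC21` gives 0.167 h as a number
- compound 3 `CS(=O)(=O)Nc1ccc2c(c1)S(=O)(=O)N=C(C1=C(O)C3CCCC3N(CC3CCC3)C1=O)N2` gives 0.0667 h as a number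

Compound 3 holds the lower of the two actual numbers in this assay, and compound 2 is its nearest neighbour. Compound 4 `CS(=O)(=O)Nc1ccc2c(c1)S(=O)(=O)N=C(C1=C(O)C3CCCC3N(Cc3cccc(F)c3)C1=O)N2` changes the group on a saturated chain carbon bound to an amide-type nitrogen in a ring. The change is 3-fluorophenyl in place of cyclobutyl on a saturated chain carbon bound to an amide-type nitrogen in a ring, which reads as cyclobutylmethyl to 3-fluorobenzyl.

Among the measured compounds shown here, no measured step makes this exact change. The closest evidence is the large step of an at least 14-fold lower number from compound 1 to compound 3 (1.17 log units; beyond the scatter), with cyclobutyl in place of 5-fluoropyridin-2-yl. The step of an at least 5.9-fold lower number from compound 1 to compound 2 (0.77 log units; beyond the scatter), with isobutyl in place of 5-fluoropyridin-2-yl, is at least modest and points the same way. The step of a 2.5-fold lower number from compound 2 to compound 3 (0.40 log units; beyond the scatter) is only modest. Only compound 1 carries an aromatic ring at this place, and that single case sets the direction. A rise of moderate size is therefore expected, with 3-fluorophenyl untested so far. The estimated step is a 4.5-fold higher number from compound 3 to compound 4 (0.65 log units; beyond the scatter) in this direction. For compound 4 the expected half-life is 0.3 h, with an estimated range of 0.1 h to 0.9 h as its span.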

Compound 4, half-life: 0.85 h
Beside the measured number, compound 4's estimate is 2.8-fold (0.45 log units) below it; measured number inside the range.
By their numbers in this assay, from the lowest: compound 3; then compound 2; then compound 4. At a limit, above all of these: compound 1.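

In this assay, 3-fluorophenyl in place of cyclobutyl gives a 13-fold higher number from compound 3 to compound 4 (1.11 log units; beyond the scatter), so the link between an aromatic ring at this place and a longer half-life no longer rests on the 5-fluoropyridin-2-yl group of compound 1 alone. The same order appears against the other saturated group, with a 5.1-fold higher number from compound 2 to compound 4 (0.71 log units; beyond the scatter), and among the compounds shown, none with a non-aromatic group at this place reaches compound 4. Compound 1 stands at a limit of the assay, not at a number: the limit of > 1 h in this assay, at which 1 of the 4 values shown sits. The remaining step, an at least 1.1-fold lower number from compound 1 to compound 4 (0.07 log units; that floor lies within the scatter), has its floor within the scatter, so no order between 3-fluorophenyl and 5-fluoropyridin-2-yl follows.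

Both aromatic groups shown carry fluorine, which leaves open whether a plain benzyl group, without fluorine, would stand with compound 4 or with the saturated groups of compound 2 and compound 3. Also open, from the compounds shown here alone, is whether a ring carrying an amine or a carboxylic acid, or a longer chain between the ring and the amide-type nitrogen, would keep the half-life of compound 4.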